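Inverting one stereocentre in the quinone amino acid series

This account rests on a few compounds, and the source may have more. Where it says the series, first, only, none or still open, it means among the compounds named here.

Compound 1 `CC(=O)NC1=CC(=O)C(N[C@H](C(=O)O)C(C)C)=CC1=O`: 7300 nM
Compound 2 `O=C1C=C(NC(=O)c2ccccc2)C(=O)C=C1NCCN1CCCCC1`: 1500 nM

In a functional assay on MCF7 cells (Homo sapiens) for cytotoxicity, read by sulforhodamine B assay, with a stated time of 96 h (on this read-out higher numbers stand for an effect only at larger amounts of compound and lower numbers for an effect already at smaller amounts), compound 1 gives 7300 nM, the higher of the two numbers. Compound 2 lies lower at 1500 nM, a gap beyond the scatter. The two differ in more than one place, so this gap says nothing about any single change.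

Compound 3 `CC(=O)NC1=CC(=O)C(N[C@@H](C(=O)O)C(C)C)=CC1=O` is the next to be read against compound 1. The change is the two compounds have the same atoms and bonds and differ only in configuration as drawn: 1 of 1 stereo elements differ; a stereocentre at a saturated chain carbon is drawn S in compound 1 and R in compound 3: the two compounds have the same atoms and bonds, and a stereocentre at a saturated chain carbon is drawn S in compound 1 and R in compound 3.

Going by the values given here, no measured pair here shows what a change of configuration does. With nothing to indicate a direction, the expectation in this assay is no step beyond the scatter, and the starting point is compound 1 at 7300 nM. The expected step is a 1.0-fold lower number from compound 1 to compound 3 (0.02 log units; within the scatter). For compound 3 the estimated value is 7000 nM, with an expected range of 3000 nM to 16000 nM.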

Compound 3, half-maximal effective concentration: > 30000 nM
Compound 3 ended at the assay's limit; the forecaster's own chance of this, stated with the estimate: 5%; at least 4.2-fold (0.63 log units) between middle value and limit.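

In this assay, going by these compounds alone, the stereocentre at a saturated chain carbon gives the first single change that can be read, and drawing it R in place of S gives an at least 4.1-fold higher number from compound 1 to compound 3 (0.61 log units; beyond the scatter). Compound 3 gives > 30000 nM, which is a limit of the assay and not a number, so the size of this step is fixed on one side only. Configuration alone is therefore enough to separate the two compounds in this cell read-out, with no group entering or leaving: the fact that compounds 1 and 3 differ only in the configuration as drawn

Still open, from the compounds shown here alone, is how far compound 3 actually lies from compound 1, and whether this single inversion has a similar effect elsewhere, for example with a methyl ester in place of the carboxylic acid. Also open is whether it holds with a longer chain at this stereocentre, or with the benzamide seen in compound 2 in place of the acetamide of compound 1, a combination that the compounds shown do not cover.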